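A few compounds are considered here, and "the series" means these few. Any claim that something is new, unique, unknown or untested is made for them only; others in the source may bear on it.

Measured in a functional assay on SW480 cells (Homo sapiens) for antiproliferative activity, read by MTT assay, with a stated time of 48 h; a lower number here means a stronger inhibitor, a higher number a weaker inhibitor:

Compound 1 `CC(CCO)n1cnc2c(Cl)ncnc21`: > 50000 nM (a limit)
Compound 2 `CCC(CCO)n1cnc2c(Cl)ncnc21`: > 50000 nM (a limit)
Compound 3 `CCCCCC(CCO)n1cnc2c(Cl)ncnc21`: > 50000 nM (a limit)

None of the three compounds has a numerical value, and the shared position is plain from the limit of > 50000 nM in this assay, at which 3 of the 3 values shown sit. As far as these compounds go, compound 3 gives only the limit > 50000 nM, so its true standing is unknown.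

Compound 4 `CCCCCC(CCO)n1cnc2cncnc21` is compound 3 with hydrogen in place of chloro on an aromatic carbon.

The measured steps, a step that the two limits leave unreadable from compound 1 to compound 2, a step that the two limits leave unreadable from compound 1 to compound 3 and a step that the two limits leave unreadable from compound 2 to compound 3, all alter the chain and leave the chloro untouched. Their sizes cannot be read, so they offer only indirect guidance on this change.

Since compound 3 rests at the limit > 50000 nM, no clear gain in this assay is expected, and a reading at the same limit seems the likeliest result. The expected change is small, and the estimated step is a step that the limit leaves unreadable from compound 3 to compound 4. For compound 4 the estimated value is 60000 nM, with an expected range from 25000 nM to 150000 nM.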

Compound 4, half-maximal inhibitory concentration: > 50000 nM
Compound 4 ended at the assay's limit; the forecaster's own chance of this, stated with the estimate: 85%; the middle value is on the limit's open side.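

Among the compounds shown here, compound 3 and compound 4 both stand at a limit in this assay, so no step between them can be read, and the size of hydrogen in place of chloro stays unknown. The compounds shown leave open how any of them truly ranks, since all share one reading: the limit of > 50000 nM in this assay, at which 4 of the 4 values shown sit.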